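Removing the Methyl from the Aromatic Oxygen of Compound 2

The compounds below may be only part of what the source reports. "The series", "measured", "known", "first", "only" and "open" are said of these compounds alone.

For the measured compounds named here, in a functional assay on Malme-3M cells (Homo sapiens) for inhibition, read by sulforhodamine B assay, with a stated time of 48 h (a lower number here means a stronger inhibitor of growth, a higher number a weaker inhibitor of growth), compound 2 `COc1cc(-c2nn(-c3cccc(NC(=O)Nc4ccc(Cl)c(C(F)(F)F)c4)c3)cc2-c2ccncc2)ccc1Cl` gives 2350 nM, the only plain number among the three compounds measured. Compound 1 `COc1cc(-c2nn(-c3cccc(NC(=O)c4cccc(C(F)(F)F)c4)c3)cc2-c2ccncc2)ccc1Cl` gives > 50000 nM, which is a limit of the assay rather than a number. Compound 3 `COc1cc(-c2nn(-c3cccc(NC(=O)c4ccccc4)c3)cc2-c2ccncc2)ccc1Cl` gives > 100000 nM, again a limit. Compound 4 `O=C(Nc1cccc(-n2cc(-c3ccncc3)c(-c3ccc(Cl)c(O)c3)n2)c1)Nc1ccc(Cl)c(C(F)(F)F)c1` differs from compound 2 by a single change: hydrogen in place of methyl on an oxygen on an aromatic ring. Going by the values given here, none of the measured steps touches this oxygen. The large steps of an at least 21-fold lower number from compound 1 to compound 2 (1.32 log units; beyond the scatter) and an at least 42-fold higher number from compound 2 to compound 3 (1.62 log units; beyond the scatter) both alter the group on the carbonyl carbon, and the step that the two limits leave unreadable from compound 1 to compound 3 cannot be read. Without any measured guide for this change, compound 4 is expected to stay close to its parent, a 1.3-fold higher number from compound 2 to compound 4 (0.11 log units; within the scatter). The estimate for compound 4 is 3000 nM, with a range from 800 nM to 12000 nM.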

Compound 4, concentration for total growth inhibition: 1650 nM
Estimate against measurement, compound 4: 1.8-fold (0.26 log units) above, within the range that was stated.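

In this assay, the swap from methoxy to hydroxy gives a 1.4-fold lower number from compound 2 to compound 4 (0.15 log units; within the scatter), so the two compounds cannot be told apart. For the compounds shown here, this is the first view of this oxygen, since all the readable earlier steps altered the group on the carbonyl carbon. The methyl on this oxygen is therefore not needed for the growth inhibition seen with compound 2. No measurement shown bears on a cause for this result. From the compounds shown here alone, whether a longer chain on this oxygen, or an amine in its place, would read the same stays open.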